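Adding a fluoro to compound 2

A few compounds are considered here, and "the series" means these few. Any claim that something is new, unique, unknown or untested is made for them only; others in the source may bear on it.

Compound 1 `O=C1C=CC(O)(c2cc3ccc(F)cc3n2S(=O)(=O)c2ccccc2)C=C1` gives 16 nM
Compound 2 `COC(=O)CCc1ccc(S(=O)(=O)n2c(C3(O)C=CC(=O)C=C3)cc3ccccc32)cc1` gives 680 nM

In a functional assay on NCI60 cells (Homo sapiens) for inhibition (on this read-out lower numbers stand for stronger inhibition of growth and higher numbers for weaker inhibition of growth), compound 2 has the higher of the two numbers, with 680 nM against compound 1 at 16 nM and a gap well beyond the scatter.

Compound 3 `COC(=O)CCc1ccc(S(=O)(=O)n2c(C3(O)C=CC(=O)C=C3)cc3ccc(F)cc32)cc1` is compound 2 with a single change fluoro in place of hydrogen on an aromatic carbon that amounts to fluoro in place of hydrogen on an aromatic carbon.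

Going by the values given here, no measured pair shows this change alone. Compound 1 also carries a fluoro and gives 16 nM but differs from compound 2 in another place too, so that gap cannot be credited to the fluoro. Only a small move is expected. The estimated step of a 1.7-fold lower number from compound 2 to compound 3 (0.23 log units; within the scatter) is toward a lower number and about the size of the scatter. For compound 3 the estimate is 400 nM with 120 nM to 1000 nM as its expected range.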

Compound 3, concentration for 50% growth inhibition: 500 nM
Estimate against measurement, compound 3: 1.3-fold (0.10 log units) below; the measured number falls inside the stated range.
By their numbers in this assay, from the lowest: compound 1; then compounds 3 and 2 (each within the scatter of the next).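

In this assay, fluoro in place of hydrogen on an aromatic carbon gives a 1.4-fold lower number from compound 2 to compound 3 (0.13 log units; within the scatter), so this first direct reading of the change at this position shows no effect that can be told from the scatter. With the fluoro present on both sides, adding the 2-(methoxycarbonyl)ethyl group gives a 31-fold higher number from compound 1 to compound 3 (1.49 log units; beyond the scatter), which ties a large difference to that chain alone. Nothing here offers an explanation for either step. From the compounds shown here alone, it remains open whether a chloro or a methoxy at the fluoro position would also stay within the scatter, and whether the fluoro step would look the same on a compound without the chain. Going by these compounds, it is also open how a shorter chain, or a carboxylic acid in place of the methyl ester, would compare with the 2-(methoxycarbonyl)ethyl group.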